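A few compounds are considered here, and "the series" means these few. Any claim that something is new, unique, unknown or untested is made for them only; others in the source may bear on it.

Measured in a functional assay on SEM cells (Homo sapiens) for cytotoxicity, with a stated time of 72 h; on this read-out higher numbers stand for an effect only at larger amounts of compound and lower numbers for an effect already at smaller amounts:
- compound 1 `C=C[C@](C)(CCCC(C)C)CCc1ccc(O)cc1`: > 36600 nM (a limit of the assay, not a number)
- compound 2 `C=C[C@@](C)(/C=C/c1ccc(O)c(C=O)c1)CCC=C(C)C`: 8510 nM

Going by the values given here, compound 2 holds the only actual number so far, 8510 nM. The one other result, for compound 1, is a limit.

Compound 3 `C=C[C@@](C)(/C=C/c1ccc(O)c(/C=C/C(=O)O)c1)CCC=C(C)C` has 2-carboxyethenyl in place of formyl on an aromatic carbon, ortho to a hydroxy group and meta to a large group (2-carboxyethenyl in place of formyl on an aromatic carbon). Among the compounds with values here, no measured pair covers this change, so the expectation is only loosely anchored on compound 2 at 8510 nM. A modest move toward larger amounts in this assay is expected, and a result within the usual scatter would not be surprising. The expected change is a 1.8-fold higher number from compound 2 to compound 3 (0.25 log units; within the scatter). For compound 3 the estimated value is 15000 nM, with an expected range of 5000 nM to 40000 nM.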

Compound 3, half-maximal effective concentration: > 36600 nM
Compound 3: a limit, no number; the forecaster's own chance of this, stated with the estimate: 35%; middle value at least 2.4-fold (0.38 log units) away from the limit.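

Within this assay the step of an at least 4.3-fold higher number from compound 2 to compound 3 (0.63 log units; beyond the scatter) is the first one-place comparison in the series, and it shows that the group on this aromatic carbon, ortho to a hydroxy group and meta to a large group, can shift the read-out beyond the scatter. Formyl remains the only group at this position with an actual number. From the compounds shown here alone, compound 3 gives > 36600 nM, which is a limit of the assay and not a number, so the step is only a minimum, and its true size stays unknown: the limit of > 36600 nM in this assay, at which 2 of the 3 values shown sit.

Going by these compounds, how much of the step belongs to the longer chain and how much to the carboxylic acid stays open; a methyl ester of the 2-carboxyethenyl group or a hydroxymethyl at this position would separate the two. Whether formyl itself is required also remains unsettled.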